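The source may report more compounds than this note shows. Statements on the series, on what has been measured and on what is new or still open speak of the compounds shown alone.

In an ADME assay on microsomes from liver (Mus musculus) for metabolic stability (a lower number here means that the compound disappears faster, a higher number that the compound lasts longer), compound 3 `CC(C)NC(=O)CC(c1ccc(-c2ccc3cccc(F)c3c2)[nH]c1=O)C(C)C` gives only a limit, < 0.0667 h. Compound 1 `CC(C)C(c1nnc[nH]1)c1ccc(-c2ccc3cccc(F)c3c2)[nH]c1=O` gives 0.213 h, and compound 2 `CC(C)C(c1cnc(N)s1)c1ccc(-c2ccc3cccc(F)c3c2)[nH]c1=O` gives 0.08 h. Compound 4 `Cc1c[nH]c(C(c2ccc(-c3ccc4cccc(F)c4c3)[nH]c2=O)C(C)C)n1` differs from compound 3 on a saturated chain carbon: 4-methyl-1H-imidazol-2-yl in place of (isopropylcarbamoyl)methyl on a saturated chain carbon bound to an aromatic carbon and a saturated chain carbon. Compounds 1 and 2 also carry a five-membered aromatic ring at this place, so the steps to compound 3 are the closest guide. These are an at least 3.1-fold lower number from compound 1 to compound 3 (0.50 log units; beyond the scatter), which is beyond the scatter, and an at least 1.1-fold lower number from compound 2 to compound 3 (0.07 log units; that floor lies within the scatter), whose floor lies within it. The choice of ring also counts, as a 2.7-fold lower number from compound 1 to compound 2 (0.43 log units; beyond the scatter) shows. Read in reverse, these steps suggest a small expected rise in this assay, an at least 1.7-fold higher number from compound 3 to compound 4 (0.25 log units; that floor lies within the scatter). For compound 4 the estimated half-life is 0.12 h, with an expected range of 0.0667 h to 0.25 h.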

Compound 4, half-life: < 0.0667 h
Compound 4 was reported as a limit; the forecaster's own chance of this, stated with the estimate: 25%; middle value at least 1.7-fold (0.25 log units) from the limit.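

Replacing the ring in compound 1 with 4-methyl-1H-imidazol-2-yl gives an at least 3.1-fold lower number from compound 1 to compound 4 (0.50 log units; beyond the scatter) in this assay, so a five-membered aromatic ring at this place does not by itself preserve the half-life. Against the 2-amino-1,3-thiazol-5-yl of compound 2, the same group gives an at least 1.1-fold lower number from compound 2 to compound 4 (0.07 log units; that floor lies within the scatter). The step from compound 3 to compound 4 cannot be read, because both values are limits: the limit of < 0.0667 h in this assay, at which 2 of the 4 values shown sit.

As far as these compounds go, it remains open how far compound 3 and compound 4 actually lie beyond that limit. Also open, from the compounds shown here alone, is whether a carboxylic acid or an amine on this saturated chain carbon would give a longer half-life than the 4H-1,2,4-triazol-3-yl of compound 1.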